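Chloro in place of hydrogen on compound 3

This account rests on a few compounds, and the source may have more. Where it says the series, first, only, none or still open, it means among the compounds named here.

In an ADME assay on C8166 cells (Homo sapiens) for cytotoxicity (on this read-out higher numbers stand for lower toxicity in this test and lower numbers for higher toxicity in this test), compound 3 `CCN1C(=O)N(c2ccc(O)c(C)c2)C(=O)N(c2ccccc2)c2cc(C(F)(F)F)ccc21` gives 17000 nM. Compound 2 `CCN1C(=O)N(c2ccc(C(=O)NC)cc2)C(=O)N(c2ccccc2)c2cc(C(F)(F)F)ccc21` gives 31000 nM in this assay, and the comparison with compound 3 reads a 1.8-fold lower number from compound 2 to compound 3 (0.26 log units; within the scatter). Compound 1 `CCN1C(=O)N(c2cccc(OC)c2)C(=O)N(c2ccccc2)c2cc(C(F)(F)F)ccc21` reports only a limit, > 20000 nM. The comparison against that limit gives only a floor, an at least 1.1-fold lower number from compound 1 to compound 3 (0.07 log units; that floor lies within the scatter).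

Compound 4 `CCN1C(=O)N(c2cc(C)c(O)c(Cl)c2)C(=O)N(c2ccccc2)c2cc(C(F)(F)F)ccc21` carries one change, chloro in place of hydrogen on an aromatic carbon: 4-hydroxy-3-methylphenyl becomes 3-chloro-4-hydroxy-5-methylphenyl, with the chloro ortho to a hydroxy group. Among the compounds with values here, no measured pair adds a chloro, so the evidence is indirect. The nearest guide is the exchange of whole aryl groups on the same nitrogen, and the one readable case, a 1.8-fold lower number from compound 2 to compound 3 (0.26 log units; within the scatter), stays within the scatter. A single added chloro is therefore not expected to move the number beyond the scatter, though a slight drift downward is allowed for. The expected change is a 1.3-fold lower number from compound 3 to compound 4 (0.12 log units; within the scatter). Compound 4 is estimated at 13000 nM, with an expected range of 6000 nM to 30000 nM.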

Compound 4, half-maximal cytotoxic concentration: > 10000 nM
Compound 4 gave a limit, no number; the forecaster's own chance of this, stated with the estimate: 20%; the middle value is on the limit's open side.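

Compound 4 reads only as a limit in this assay: the limit of > 10000 nM in this assay, at which 1 of the 4 values shown sits.

Its steps from compound 1, compound 2 and compound 3 therefore cannot be read. The compounds shown leave open whether chloro in place of hydrogen on compound 3 shifts the read-out at all, and in which direction.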